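Methylating the phenol of compound 1: what to expect

The source may report more compounds than this note shows. Statements on the series, on what has been measured and on what is new or still open speak of the compounds shown alone.

Measured compounds in an assay on isolated protein for inhibition of thiosulfate sulfurtransferase (Homo sapiens), with a stated time of 60 min, in the absence of a further agent; on this read-out higher numbers stand for weaker inhibition and lower numbers for stronger inhibition:
compound 1, `O=C(Nc1ccc(Sc2nc3ccccc3s2)c(Cl)c1)c1cccc(Br)c1O`, gives > 100000 nM, a limit of the assay rather than a number.
compound 2, `O=C(Nc1ccccc1)c1cc(Br)cc(Br)c1O`, gives > 100000 nM, again a limit of the assay.
compound 3, `O=C(Nc1ccc(Sc2nc3ccccc3s2)cc1)c1cccc(Br)c1O`, gives > 100000 nM, again a limit of the assay.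

Compound 1 thus stands at a limit in this assay, and the two other values are limits as well. For the measured compounds named here, the only single-point step among the measured compounds, a step that the two limits leave unreadable from compound 1 to compound 3, cannot be read because both ends sit at the limit of > 100000 nM in this assay, at which 3 of the 3 values shown sit. Going by the values given here, no measured step therefore tells how large a change in this assay to expect from a small edit to compound 1.

Compound 4, `COc1c(Br)cccc1C(=O)Nc1ccc(Sc2nc3ccccc3s2)c(Cl)c1`, differs from compound 1 by methyl in place of hydrogen on an oxygen on an aromatic ring. Among the compounds with values here, no measured step bears on this change. Given that every value shown sits at the limit of > 100000 nM in this assay, at which 3 of the 3 values shown sit, the expectation for compound 4 is that this assay again reports only a limit, with an estimated value of 100000 nM between 30000 nM and 300000 nM. The step from compound 1 to compound 4 is thus expected to be a number no higher from compound 1 to compound 4 (the limit leaves the size open), that is, nothing readable beyond the scatter.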

Compound 4, half-maximal inhibitory concentration: > 100000 nM
Compound 4: only a limit was reported; the forecaster's own chance of this, stated with the estimate: 85%; the middle value lies on the limit itself.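

Compound 4 gives > 100000 nM, which is a limit and not a number. Compound 1 also sits at a limit, so the change from hydroxy to methoxy between compound 1 and compound 4 cannot be read as a step. The compounds shown leave open how any small edit changes inhibition, because none of them gives a number: the limit of > 100000 nM in this assay, at which 4 of the 4 values shown sit.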